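Opening the oxetane ring: an estimate for compound 4

A few compounds are considered here, and "the series" means these few. Any claim that something is new, unique, unknown or untested is made for them only; others in the source may bear on it.

Of the compounds shown here, three have been measured in an assay on isolated protein for inhibition of Aromatase (Homo sapiens), tested at 1 uM; a higher number here means more inhibition at the concentration tested (going by the name of the read-out), a lower number less inhibition. Compound 1 `C[C@@H](c1ccc(Cl)cc1)N1Cc2cncn2C(CC2(C)COC2)S1(=O)=O` gives 35%, the highest of the three numbers. In this assay compound 2 `CC(C)CC1n2cncc2CN(C2CC2)S1(=O)=O` gives 9%, and compound 3 `CC(C)CC1n2cncc2CN(Cc2ccccc2)S1(=O)=O` gives 14%; each of these two lies beyond the scatter below compound 1. Among the measured compounds shown here, the only one-place step among the measured compounds, a number 5 percentage points higher from compound 2 to compound 3 (within the scatter), concerns the group on the sulfonamide nitrogen and stays within the scatter.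

Compound 4 `COC(C)(C)CC1n2cncc2CN([C@@H](C)c2ccc(Cl)cc2)S1(=O)=O` differs from compound 1 in one place: 1-methoxy-1-methylethyl in place of 3-methyloxetan-3-yl on a saturated chain carbon bound to a saturated ring carbon. For the measured compounds named here, no measured step touches this part of the shared core, so the measured step between compound 2 and compound 3 does not bear on the change, and the expectation rests on compound 1 alone. The leaving and entering groups match in their counts of heavy atoms and of hydrogen-bond acceptors, which gives no ground to expect a shift in either direction. The step of a number 3 percentage points lower from compound 1 to compound 4 (within the scatter) is therefore expected to stay within the usual scatter. Compound 4 is estimated at 32%, with a range from 12% to 52%.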

Compound 4, a percentage reported as inhibition, at one concentration (the size of the read-out at that concentration, not a potency): 17%
Estimate against measurement, compound 4: 15 percentage points above, within the range that was stated.
By their numbers in this assay, from the lowest: compounds 2, 3 and 4 (each within the scatter of the next); then compound 1.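

In this assay, among the compounds shown here, replacing 3-methyloxetan-3-yl with 1-methoxy-1-methylethyl gives a number 18 percentage points lower from compound 1 to compound 4 (beyond the scatter) and this is the first measured step at this place, on a saturated chain carbon bound to a saturated ring carbon. It shows that the number responds to this part of the molecule even when the counts of heavy atoms and hydrogen-bond acceptors stay the same. Of the features counted, the one that differs is the four-membered non-aromatic ring, present in the leaving group and absent from the entering one, although nothing here explains the drop.

A single step cannot show whether the ring itself or the placing of the oxygen matters more. As far as these compounds go, a carbon-only cyclobutyl ring, an amine or a longer chain at this place would each test that question further, and their effects remain open.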